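The source may hold more compounds than are shown below. What is called first, only, known or untested is meant among the compounds shown, and "the series" means these compounds.

In an ADME assay on microsomes from liver (Homo sapiens) for metabolic stability, using NADPH, with a stated time of 40 min, tested at 2 uM (on this read-out higher numbers stand for a longer-lived compound and lower numbers for a shorter-lived compound), compound 1 (`Fc1cc(Cl)c2[nH]cc(-c3ccc4ccccc4n3)c2c1`) gives 0.383 h and compound 2 (`Fc1cc(F)c2[nH]cc(-c3ccc4ccccc4n3)c2c1`) gives 0.45 h. These two numbers cannot be told apart, since the measured step is a 1.2-fold higher number from compound 1 to compound 2 (0.07 log units; within the scatter). Compound 3 (`Fc1cc(Cl)cc2c(-c3ccc4ccccc4n3)c[nH]c12`) comes from compound 2 by a single exchange: chloro in place of fluoro on an aromatic carbon, meta to a fluoro group. Among the compounds with values here, only one measured step bears on this. It is the same kind of exchange in the opposite direction, on a different carbon, so it is only a loose guide: a 1.2-fold higher number from compound 1 to compound 2 (0.07 log units; within the scatter). Compound 3 also carries both fluoro and chloro, as does compound 1 at 0.383 h. No shift beyond the scatter is therefore expected in this assay, and the estimated step is a 1.2-fold lower number from compound 2 to compound 3 (0.06 log units; within the scatter). For compound 3 the expected half-life is 0.39 h, with an estimated range of 0.2 h to 0.75 h.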

Compound 3, half-life: 0.633 h
Estimate against measurement, compound 3: 1.6-fold (0.21 log units) below; measured number inside the range.
By their numbers in this assay, from the lowest: compounds 1, 2 and 3 (each within the scatter of the next).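

In this assay, chloro in place of fluoro on this carbon, meta to a fluoro group and para to a fused ring, gives a 1.4-fold higher number from compound 2 to compound 3 (0.15 log units; within the scatter), so either halogen can sit here with no readable change in half-life. The earlier step, a 1.2-fold higher number from compound 1 to compound 2 (0.07 log units; within the scatter), concerned a different carbon, and this result shows that an exchange between these two halogens also stays within the scatter at a second place on the shared core. Nothing measured here offers an explanation for either result.

Fluoro and chloro are the only groups shown on this carbon, so it remains open whether half-life can be moved beyond the scatter from here. An amine, a methoxy group or a carboxylic acid at this position might behave quite differently from either halogen.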